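Benzofuran in place of furan on the shared core

The source may hold more compounds than are shown below. What is called first, only, known or untested is meant among the compounds shown, and "the series" means these compounds.

Measured so far:
compound 1 `Cc1ccccc1-n1nc(C)c2c1NC(=O)[C@H](C)S[C@@H]2c1ccc(-c2ccoc2)cc1` gives 40%
compound 2 `CCc1ccccc1-n1nc(C)c2c1NC(=O)[C@H](C)S[C@@H]2c1ccc(Oc2ccccc2)cc1` gives 190%
compound 3 `CCCc1ccccc1-n1nc(C)c2c1NC(=O)[C@H](C)S[C@@H]2c1ccc(Oc2ccccc2)cc1` gives 240%

All three were read in an assay on isolated protein for agonist activity at Bile acid receptor (Homo sapiens), read by AlphaScreen, with a stated time of 30 min; a lower number here means a smaller maximal response, a higher number a larger maximal response. Compound 1 stands lowest of the three numbers: compound 2 lies well above it and compound 3 further still, both gaps beyond the scatter. Within the data shown here, the only single-point step among the measured compounds is a number 50 percentage points higher from compound 2 to compound 3 (beyond the scatter), a methyl in place of hydrogen on the chain carried by the aryl group on the ring nitrogen; it does not touch the part of the molecule changed here.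

Compound 4 `Cc1ccccc1-n1nc(C)c2c1NC(=O)[C@H](C)S[C@@H]2c1ccc(-c2cc3ccccc3o2)cc1` differs from compound 1 as follows: 1-benzofuran-2-yl in place of furan-3-yl on an aromatic carbon. Among the measured compounds shown here, no measured pair shows this kind of change, so nothing in the data fixes its size or direction. With compound 1 sitting at the bottom of the range, more room lies upward than downward; the step of a number 30 percentage points higher from compound 1 to compound 4 (beyond the scatter) is expected to be modest, with wide uncertainty. Compound 4 is estimated at 70%, within 20% to 160%.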

Compound 4, largest response reached (reported as efficacy), in percent of the reference or control that the assay uses: 17%
For compound 4 the middle estimate is 53 percentage points above the measured one; measured number outside the range, below it.
By their numbers in this assay, from the lowest: compound 4; then compound 1; then compound 2; then compound 3.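

Among these compounds, replacing furan-3-yl with 1-benzofuran-2-yl on this aromatic carbon gives, in this assay, a number 23 percentage points lower from compound 1 to compound 4 (beyond the scatter), the first single-point reading at this place. The maximal response therefore depends on the group carried here, and going from 5 to 9 heavy atoms, with an added six-membered aromatic ring of carbon only, does not raise it in this pair. Nothing measured accounts for the drop.

This pair changes both the ring count and the point of attachment, from 3-yl to 2-yl, so it cannot show which of the two matters; furan-2-yl at this place would separate them. Also open, on these data alone, is how the response would shift with an amine or a carboxylic acid on the 1-benzofuran-2-yl group.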